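Swapping a ring substituent on a quinazoline thiosemicarbazide

A few compounds are considered here, and "the series" means these few. Any claim that something is new, unique, unknown or untested is made for them only; others in the source may bear on it.

Measured compounds:
Compound 1, `COc1cc2ncnc(NNC(=S)NC(=O)c3ccccc3Cl)c2cc1OC`, gives 23100 nM.
Compound 2, `COc1cc2ncnc(NNC(=S)NC(=O)c3ccc(C)cc3)c2cc1OC`, gives 22300 nM.
Compound 3, `Cc1ccc(C(=O)NC(=S)NNc2ncnc3ccccc23)cc1`, gives 7820 nM.

These values come from a functional assay on MCF7 cells (Homo sapiens) for cytotoxicity, read by MTT assay, with a stated time of 72 h; on this read-out lower numbers stand for stronger inhibition and higher numbers for weaker inhibition. Compound 3 has the lowest number of the three; the difference between its core and that of compound 2 is not broken down here. Compound 4, `O=C(NC(=S)NNc1ncnc2ccccc12)c1ccccc1Cl`, is not yet measured. It arises from compound 3 by 2-chlorophenyl in place of 4-methylphenyl on a carbonyl carbon. The same change, (2-chlorophenyl in place of 4-methylphenyl on a carbonyl carbon), is already known from the pair of compounds 2 and 1, where it gave a 1.0-fold higher number from compound 2 to compound 1 (0.02 log units; within the scatter), a step within the scatter. Because that step a 1.0-fold higher number from compound 2 to compound 1 (0.02 log units; within the scatter) was flat, a similarly flat step is expected for a 1.0-fold higher number from compound 3 to compound 4 (0.01 log units; within the scatter). Within the data shown here, compound 4 is therefore estimated at 8000 nM in this assay, with a likely range from 3500 nM to 18000 nM, resting on the single earlier example only.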

Compound 4, half-maximal inhibitory concentration: 10500 nM
Beside the measured number, compound 4's estimate is 1.3-fold (0.12 log units) below it, within the range that was stated.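

In this assay, putting 2-chlorophenyl in place of 4-methylphenyl on a carbonyl carbon gives a 1.3-fold higher number from compound 3 to compound 4 (0.13 log units; within the scatter) and so stays flat on this second core as well. The change behaves alike on both cores, with no difference between them that exceeds normal assay scatter: the same change on two cores in this assay, a 1.0-fold higher number (0.02 log units; within the scatter) from compound 2 to compound 1 and a 1.3-fold higher number (0.13 log units; within the scatter) from compound 3 to compound 4, 1.3-fold (0.11 log units) apart, within the scatter of two such steps. Among these compounds, this rests on only two pairs in one cell assay, so it does not show that the same flat result would hold on further cores or that other changes would carry over in this way.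

From the compounds shown here alone, it remains open whether an amine or a carboxylic acid on the phenyl ring would move the number. Going by these compounds, the effect of a longer chain in place of the ring on the carbonyl carbon is also open.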